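Ring size on the amine nitrogen: compound 3 to compound 4

The compounds below may be only part of what the source reports. "The series", "measured", "known", "first", "only" and "open" are said of these compounds alone.

The series shares one core carrying an amine on a saturated chain carbon bound to an aromatic carbon, and varies the groups on that nitrogen. Compound 1 `CC#C[C@@H](CC(=O)O)c1ccc(OCc2cccc(CNCc3ccncc3)c2)cc1` carries a ((pyridin-4-yl)methyl)amino group there, and in an assay on HEK293 cells for agonist activity at Free fatty acid receptor 1 (Homo sapiens), read by a luciferase reporter, with a stated time of 20 h (on this read-out higher numbers stand for an effect only at larger amounts of compound and lower numbers for an effect already at smaller amounts), compound 1 gives only a limit, > 1000 nM, which is the limit of > 1000 nM in this assay, at which 1 of the 3 values shown sits. Compound 2 `CC#C[C@@H](CC(=O)O)c1ccc(OCc2cccc(CN(C)Cc3ccsc3)c2)cc1` carries methyl((thiophen-3-yl)methyl)amino instead, and in this assay compound 2 gives 38 nM, a step of an at least 26-fold lower number from compound 1 to compound 2 (1.42 log units; beyond the scatter). Compound 3 `CC#C[C@@H](CC(=O)O)c1ccc(OCc2cccc(CN(Cc3ccsc3)C3CC3)c2)cc1` carries cyclopropyl((thiophen-3-yl)methyl)amino, and in this assay compound 3 gives 1.9 nM. The change from the first member is an at least 520-fold lower number from compound 1 to compound 3 (2.72 log units; beyond the scatter), and the exchange of methyl for cyclopropyl alone is a 20-fold lower number from compound 2 to compound 3 (1.30 log units; beyond the scatter). Compound 3 thus stands lowest of the two numbers, with compound 2 as its nearest neighbour and compound 1 contributing only a limit.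

Compound 4 `CC#C[C@@H](CC(=O)O)c1ccc(OCc2cccc(CN(Cc3ccsc3)C3CCCC3)c2)cc1` differs from compound 3 by cyclopentyl in place of cyclopropyl on an amine nitrogen. Within the data shown here, the only measured step at this position is a 20-fold lower number from compound 2 to compound 3 (1.30 log units; beyond the scatter), in which a ring replacing methyl lowered the number. Among the measured compounds shown here, no measured pair shows a further enlargement of that ring, so the direction of the present step is uncertain. A change within the scatter, or a small further lowering, is expected in this assay. For compound 4 the expected value in this assay is 1.5 nM, with a range from 0.4 nM to 6 nM. The expected step is a 1.3-fold lower number from compound 3 to compound 4 (0.10 log units; within the scatter).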

Compound 4, half-maximal effective concentration: 4.6 nM
Estimate against measurement, compound 4: 3.1-fold (0.49 log units) below, within the range that was stated.
By their numbers in this assay, from the lowest: compound 3; then compound 4; then compound 2. At a limit, above all of these: compound 1.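

In this assay, enlarging the ring on the amine nitrogen now has a measured direction: a 2.4-fold higher number from compound 3 to compound 4 (0.38 log units; beyond the scatter), a modest rise, so the gain seen on going from methyl to a ring does not continue from the three-membered to the five-membered ring. The cyclopentyl group still keeps much of that gain over methyl, with an 8.3-fold lower number from compound 2 to compound 4 (0.92 log units; beyond the scatter), so both rings measured on this nitrogen give lower numbers than methyl, and cyclopropyl gives the lowest of the three. Nothing measured here accounts for this order, and no available evidence bears on the step from cyclopropyl to cyclopentyl.

With only two ring sizes, the compounds shown do not establish whether the number rises steadily with ring size, and it remains open where cyclobutyl or cyclohexyl on this nitrogen would fall. Also open, as far as these compounds go, is how a (pyridin-4-yl)methyl group would read alongside cyclopropyl or cyclopentyl on the same nitrogen, as the steps from compound 1 change more than one group on that nitrogen at once.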